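A few compounds are considered here, and "the series" means these few. Any claim that something is new, unique, unknown or untested is made for them only; others in the source may bear on it.

In a functional assay on A549 cells (Homo sapiens) for cytotoxicity, read by MTT assay, with a stated time of 72 h (a lower number here means a stronger inhibitor, a higher number a weaker inhibitor), the measured compounds are:
Compound 1 `COc1ccc(Nc2nc3ccccc3nc2S(=O)(=O)c2ccccc2)cc1` gives 11900 nM
Compound 2 `Nc1cccc(Nc2nc3ccccc3nc2S(=O)(=O)c2ccccc2)c1` gives 1590 nM
Compound 3 `COc1ccc(Nc2nc3ccccc3nc2S(=O)(=O)c2ccc(C)cc2)cc1` gives > 50000 nM as a limit, not a number

Compound 3 stands at the limit of > 50000 nM in this assay, at which 1 of the 3 values shown sits, and so offers a limit only.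

Compound 4 `Cc1ccc(S(=O)(=O)c2nc3ccccc3nc2Nc2cccc(N)c2)cc1` keeps the methyl of compound 3 and changes one group, with 3-aminophenyl in place of 4-methoxyphenyl on a nitrogen on an aromatic ring. The counted difference is 3-aminophenyl in place of 4-methoxyphenyl on a nitrogen on an aromatic ring in full.

This same swap has been measured once, in the absence of the methyl, as a 7.5-fold lower number from compound 1 to compound 2 (0.87 log units; beyond the scatter) and that single pair is the closest guide. It points to a lower number of about that size, a stronger inhibitor. The methyl has also been measured, as an at least 4.2-fold higher number from compound 1 to compound 3 (0.62 log units; beyond the scatter) and it worked in the opposite direction. Compound 4 carries that methyl, so it is expected to stay a weaker inhibitor than compound 2 at 1590 nM on this evidence.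

The expected change is an at least 6.2-fold lower number from compound 3 to compound 4 (0.79 log units; beyond the scatter) and its size stays uncertain, since the starting point is only a limit.

For compound 4 the estimated value is 8000 nM within an expected range of 2500 nM to 35000 nM in this assay.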

Compound 4, half-maximal inhibitory concentration: 1950 nM
Compound 4: the middle estimate sits 4.1-fold (0.61 log units) above what was measured; measured number outside the range, below it.
By their numbers in this assay, from the lowest: compounds 2 and 4 (each within the scatter of the next); then compound 1. At a limit, above all of these: compound 3.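

In this assay, putting 3-aminophenyl in place of 4-methoxyphenyl on the nitrogen also works when the methyl is present, giving an at least 25-fold lower number from compound 3 to compound 4 (1.40 log units; beyond the scatter), and the step on this core differs from the one on the core without the methyl: the same change on two cores in this assay, a 7.5-fold lower number (0.87 log units; beyond the scatter) from compound 1 to compound 2 and an at least 25-fold lower number (1.40 log units; beyond the scatter) from compound 3 to compound 4, at least 3.4-fold (0.53 log units) apart, beyond the scatter of two such steps. Compound 3 gives > 50000 nM, which is a limit and not a number. With 3-aminophenyl in place, the methyl on the aromatic carbon gives only a 1.2-fold higher number from compound 2 to compound 4 (0.09 log units; within the scatter), so the two changes do not simply add up, and the loss seen with the methyl in the 4-methoxyphenyl pair does not carry over: the same change on two cores in this assay, an at least 4.2-fold higher number (0.62 log units; beyond the scatter) from compound 1 to compound 3 and a 1.2-fold higher number (0.09 log units; within the scatter) from compound 2 to compound 4, at least 3.4-fold (0.53 log units) apart, beyond the scatter of two such steps.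

The compounds shown leave open whether the amine itself matters, which a hydroxyl or an acetamide in its place on the phenyl ring could help to settle. They also leave open whether the tolerance of the methyl in the 3-aminophenyl series extends to other groups in its place, such as a chlorine or an ethyl.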